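Swapping two chlorines for a nitrile on the sulfonyl ring

The compounds below may be only part of what the source reports. "The series", "measured", "known", "first", "only" and "open" are said of these compounds alone.

Compound 1 `CC1CCN(c2c(S(=O)(=O)c3ccc(Cl)cc3)cnc3cc(Cl)ccc23)CC1`: in an assay on isolated protein for displacement of a labelled ligand from metabotropic glutamate receptor 5 (Homo sapiens), with a stated time of 60 min, tested at 1 uM (a higher number here means more inhibition at the concentration tested (going by the name of the read-out), a lower number less inhibition), compound 1 gives 91%.
Compound 2 `CC1CCN(c2c(S(=O)(=O)c3ccc(F)cc3)cnc3cc(Cl)ccc23)CC1`: in this assay compound 2 gives 91%.
Compound 3 `CC1CCN(c2c(S(=O)(=O)c3cc(Cl)cc(Cl)c3)cnc3cc(Cl)ccc23)CC1`: in this assay compound 3 gives 93%.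

Compound 3 holds the highest of the three numbers, but only nominally: a number 2 percentage points higher from compound 1 to compound 3 (within the scatter) and a number 2 percentage points higher from compound 2 to compound 3 (within the scatter), both within the scatter, so the three compounds cannot be told apart on these figures. Compound 4 `CC1CCN(c2c(S(=O)(=O)c3cccc(C#N)c3)cnc3cc(Cl)ccc23)CC1` differs from compound 3 in one place: 3-cyanophenyl in place of 3,5-dichlorophenyl on a sulfonyl sulfur. The measured steps that bear on this are the two that also alter the ring on the sulfonyl sulfur, a number 2 percentage points higher from compound 1 to compound 3 (within the scatter) and a number 2 percentage points higher from compound 2 to compound 3 (within the scatter), together with no change at the digits printed from compound 1 to compound 2 (within the scatter); none of them moved beyond the scatter. For the measured compounds named here, no measured compound carries a nitrile, so the step to compound 4 rests only on the observation that every change at this ring so far left the read-out high. Compound 4 is therefore expected to stay near the others, with an expected step of a number 8 percentage points lower from compound 3 to compound 4 (within the scatter), leaving room for a modest fall. The estimate for compound 4 is 85%, with a range from 65% to 96%.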

Compound 4, a percentage reported as inhibition, at one concentration (the size of the read-out at that concentration, not a potency): 94%
Compound 4: the middle estimate sits 9 percentage points below what was measured; measured number inside the range.
By their numbers in this assay, from the lowest: compounds 1, 2, 3 and 4 (each within the scatter of the next).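

Compound 4 brings a nitrile onto the ring on the sulfonyl sulfur, and in this assay the read-out stays level with the three halogen-bearing rings (a number 1 percentage points higher from compound 3 to compound 4 (within the scatter)), (a number 3 percentage points higher from compound 2 to compound 4 (within the scatter)) and (a number 3 percentage points higher from compound 1 to compound 4 (within the scatter)). So among these four compounds, this position accepts a ring with no halogen on it, and a triple bond and a hydrogen-bond acceptor enter there without any change beyond the scatter. Nothing at hand explains why this swap leaves the read-out where it stands.

All four numbers lie so close together at one tested concentration that they do not rank the compounds, so any real differences in potency stay hidden. Going by these compounds, it also remains open whether this position would hold up with an amine, a carboxylic acid or a longer chain on the ring, or with the ring replaced by a plain methyl group.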